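Chloro position swap on the ring-amine aryl group

This account rests on a few compounds, and the source may have more. Where it says the series, first, only, none or still open, it means among the compounds named here.

Measured so far:
compound 1 `CCCc1nc(-c2ccccc2)c(CNCCN2CCN(c3ccc(F)cc3)CC2)o1` — 7080 nM
compound 2 `CCCc1nc(-c2ccccc2)c(CNCCCN2CCN(c3cccc(Cl)c3)CC2)o1` — 1750 nM

In an assay on HEK293 cells for inhibition of Voltage-dependent T-type calcium channel subunit alpha-1G (Homo sapiens), read by patch clamp (on this read-out lower numbers stand for stronger inhibition and higher numbers for weaker inhibition), compound 2 gives 1750 nM, the lowest of the two numbers; compound 1 gives 7080 nM, a higher number beyond the scatter. Compound 1 and compound 2 differ in two places at once, so no single step can be read from them. Compound 3 `CCCc1nc(-c2ccccc2)c(CNCCCN2CCN(c3ccc(Cl)cc3)CC2)o1` differs from compound 2 only by 4-chlorophenyl in place of 3-chlorophenyl on an amine nitrogen in a ring. Within the data shown here, no measured pair shows this kind of change, so the step from compound 2 to compound 3 is expected to be small, likely within the scatter, in either direction. Compound 3 is estimated at 2200 nM, between 700 nM and 7000 nM, meaning a step of a 1.3-fold higher number from compound 2 to compound 3 (0.10 log units; within the scatter) in this assay.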

Compound 3, half-maximal inhibitory concentration: 1310 nM
Beside the measured number, compound 3's estimate is 1.7-fold (0.23 log units) above it, within the range that was stated.
By their numbers in this assay, from the lowest: compounds 3 and 2 (each within the scatter of the next); then compound 1.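

In this assay, 4-chlorophenyl in place of 3-chlorophenyl on the ring amine nitrogen gives a 1.3-fold lower number from compound 2 to compound 3 (0.13 log units; within the scatter) and stays within the scatter, so this first single-place comparison separates the two chlorophenyl groups by no readable difference. Steps from compound 1 to compound 2 or compound 3 cannot be read, as each spans two places. Nothing on hand bears on why these two groups read alike.

Still open, going by these compounds, is how a methoxy group or a nitrile on this phenyl ring would read. On these data alone, the effect of the chain length alone also remains open.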